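Working notes: compound 4 in the cytotoxicity series

The source may report more compounds than this note shows. Statements on the series, on what has been measured and on what is new or still open speak of the compounds shown alone.

The series has three measured members. Compound 1 `Fc1cccc(F)c1Cn1c(-c2c(F)cccc2F)nc2cnccc21` was tested in an ADME assay on MDBK cells (Bos taurus) for cytotoxicity; a lower number here means that less compound is tolerated, a higher number that more compound is tolerated. For compound 1 the result is a limit of the assay, > 100000 nM. Compound 2 `Fc1cccc(F)c1-c1nc2ccn(Cc3ccccc3)cc-2n1` likewise sits at a limit, > 100000 nM. Compound 3 `Cc1ccc(Cn2ccc3nc(-c4ccccc4)nc-3c2)cc1` gives only a limit as well, > 100000 nM. Thus compound 3 stands where every measured member stands, at the limit of > 100000 nM in this assay, at which 3 of the 3 values shown sit; no number separates it from compound 1 or compound 2, and no step among the three can be sized.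

Compound 4 `CC(C)=CCn1ccc2nc(-c3ccccc3)nc-2c1` has not yet been measured. It differs from compound 3 by 2-methylprop-1-en-1-yl in place of 4-methylphenyl on a saturated chain carbon bound to an aromatic nitrogen. With every measured value sitting at the same limit, no direction can be read for this change, and it is expected to produce no step beyond the scatter, estimated as a number no higher from compound 3 to compound 4 (the limit leaves the size open). For compound 4 in this assay the estimate is 100000 nM, within 40000 nM to 250000 nM, and the likeliest outcome is that the assay again reports a limit rather than a number.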

Compound 4, half-maximal cytotoxic concentration: > 100000 nM
Compound 4 gave a limit, no number (the forecaster's own chance of this, stated with the estimate: 80%); the middle value lies on the limit itself.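

In this assay no step can be read between compound 3 and compound 4, whose results are both limits of the assay and not numbers. The compounds shown leave open the concentration at which any of them becomes cytotoxic, and whether 2-methylprop-1-en-1-yl and 4-methylphenyl differ in this read-out.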